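A Methoxy Added to a Weakly Active Hydrazone

A few compounds are considered here, and "the series" means these few. Any claim that something is new, unique, unknown or untested is made for them only; others in the source may bear on it.

The shared core of these compounds carries a sulfonyl-linked morpholine and an acyl hydrazone. Compound 1 `C/C(=N\NC(=O)c1cccc(S(=O)(=O)N2CCOCC2)c1)c1cc(O)ccc1O` reaches only a limit in a functional assay on MCF7 cells (Homo sapiens) for antiproliferative activity, read by MTT assay, with a stated time of 72 h (on this read-out lower numbers stand for stronger inhibition and higher numbers for weaker inhibition), recorded as > 100000 nM. Compound 2 `O=C(N/N=C/c1ccco1)c1cccc(S(=O)(=O)N2CCOCC2)c1` likewise gives only a limit in this assay, > 100000 nM. Going by the values given here, compound 3 `O=C(N/N=C/c1ccccc1O)c1cccc(S(=O)(=O)N2CCOCC2)c1` is the sole compound with an actual number: in this assay compound 3 gives 29100 nM. Among the compounds with values here, the single measured step, an at least 3.4-fold lower number from compound 2 to compound 3 (0.53 log units; beyond the scatter), is thus set against the limit of > 100000 nM in this assay, at which 2 of the 3 values shown sit, rather than against a second number.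

Compound 4 `COc1ccc(/C=N/NC(=O)c2cccc(S(=O)(=O)N3CCOCC3)c2)c(O)c1` differs from compound 3 by methoxy in place of hydrogen on an aromatic carbon. Within the data shown here, no measured step involves a methoxy group, so nothing in the data speaks directly to this change. Set beside the step of an at least 3.4-fold lower number from compound 2 to compound 3 (0.53 log units; beyond the scatter), which exchanged one ring for another, the addition of a methoxy is a smaller change, and the expected step in this assay is none beyond the scatter, or at most a modest one in either direction. Compound 4 is therefore expected to give about 20000 nM in this assay, within a range from 6000 nM to 70000 nM. The step this estimate implies is expected to be a 1.5-fold lower number from compound 3 to compound 4 (0.16 log units; within the scatter).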

Compound 4, half-maximal inhibitory concentration: 5140 nM
Compound 4: the middle estimate sits 3.9-fold (0.59 log units) above what was measured; the measured number lies below the stated range.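

Methoxy in place of hydrogen on an aromatic carbon, meta to a hydroxy group and para to a large group, is the only change shown that alters the 2-hydroxyphenyl ring while keeping it in place, and in this assay it gives a 5.7-fold lower number from compound 3 to compound 4 (0.75 log units; beyond the scatter). Going by these compounds alone, the earlier compounds showed only that exchanging one ring for another could move the number, whereas this step shows that a small addition to the ring, of 2 heavy atoms, can also carry a change beyond the scatter. With 2-hydroxy-4-methoxyphenyl in place of furan-2-yl the step grows to an at least 19-fold lower number from compound 2 to compound 4 (1.28 log units; beyond the scatter), but it is counted from a limit rather than from a number, so its full size stays unknown: the limit of > 100000 nM in this assay, at which 2 of the 4 values shown sit.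

The compounds shown leave open whether the lower number is particular to methoxy, or whether an ethoxy, a fluorine or an amine on the same carbon would give a similar step. They also leave open whether methoxy on another carbon of this ring would do the same, and whether a 4-methoxyphenyl group without the hydroxy would keep the step.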